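A Chlorine Added to the Benzyl Group of Compound 1

The compounds below may be only part of what the source reports. "The series", "measured", "known", "first", "only" and "open" are said of these compounds alone.

Measured compounds:
compound 1 `Cc1ccc2[nH]c(-n3[nH]c(C)c(Cc4ccccc4)c3=O)nc2c1` gives 35%
compound 2 `Cc1[nH]n(-c2nc3cc(C(F)(F)F)ccc3[nH]2)c(=O)c1Cc1ccccc1` gives 78%
compound 3 `Cc1nn(-c2nc3ccccc3[nH]2)c(O)c1Cc1ccccc1` gives 42%

Three compounds have been run in a functional assay on DU-145 cells (Homo sapiens) for antiproliferative activity, read by WST assay, with a stated time of 48 h, tested at 1 uM; on this read-out higher numbers stand for a stronger effect at the one concentration tested and lower numbers for a weaker effect. Compound 1 stands lowest of the three numbers. Its nearest neighbour is compound 3, whose value lies within the usual scatter of that of compound 1, so the two cannot be told apart. Among the compounds with values here, compound 2 lies furthest away, and the one step between compounds that differ in a single place runs to it: a number 43 percentage points higher from compound 1 to compound 2 (beyond the scatter). That step changes a group on the shared core, not the benzyl group.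

Compound 4 `Cc1ccc2[nH]c(-n3[nH]c(C)c(Cc4ccc(Cl)cc4)c3=O)nc2c1` differs from compound 1 by chloro in place of hydrogen on an aromatic carbon. Within the data shown here, no measured step touches the benzyl group, so the measured data give no guidance on this change, and nothing points to a step beyond the scatter. The step from compound 1 to compound 4 is therefore expected to be a number 7 percentage points higher from compound 1 to compound 4 (within the scatter). For compound 4 the estimated value in this assay is 42%, with a range from 20% to 65%.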

Compound 4, a percentage reported as inhibition, at one concentration (the size of the read-out at that concentration, not a potency): -1%
The estimate for compound 4 lay 43 percentage points above the measured number; measured number outside the range, below it.
By their numbers in this assay, from the lowest: compound 4; then compounds 1 and 3 (each within the scatter of the next); then compound 2.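

The benzyl group of compound 1 is not a silent part of the molecule: in this assay, going from benzyl to 4-chlorobenzyl gives a number 36 percentage points lower from compound 1 to compound 4 (beyond the scatter), and compound 4, at -1%, shows no inhibition at the one concentration tested. The earlier step changed a group on the shared core and raised the number, whereas this one, on the benzyl ring, lowers it, so the number responds to changes in both places and not in the same direction. No measurement here explains why one added chlorine has this effect.

Going by these compounds, it remains open whether any group at this place lowers the number or whether this holds for chloro in particular, which fluoro or methoxy on the same carbon could help to settle. Also open, on these data alone, is whether chloro has the same effect on compound 2, which carries trifluoromethyl on the core.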